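The source may hold more compounds than are shown below. What is called first, only, known or untested is meant among the compounds shown, and "the series" means these compounds.

Measured compounds:
- Compound 1, `CCCCC[Se]c1nc([Se]CCCCC)c2ccccc2n1`, gives 65700 nM in a functional assay on CCRF-CEM cells (Homo sapiens) for cytotoxicity, read by MTT assay, with a stated time of 72 h; on this read-out lower numbers stand for stronger inhibition of growth and higher numbers for weaker inhibition of growth.
- Compound 2, `CSc1nc(NCCCc2ccccc2)c2ccccc2n1`, gives 39500 nM in this assay.

Compound 2 has the lower of these two numbers, but its gap to compound 1 lies within the usual scatter of repeated measurements, so the two cannot be told apart on these data. Compound 3, `CSc1nc(NCCCCc2ccccc2)c2ccccc2n1`, shares the core of compound 2 and differs from it in one place: benzyl in place of phenyl on a saturated chain carbon, three bonds along the chain from a nitrogen on an aromatic ring. The chain that ends in the aromatic ring is thus one link longer, and nothing else changes. Among the compounds with values here, no measured pair shows the effect of such a change, so the expectation rests on compound 2 alone: a step from compound 2 to compound 3 in this assay of a 1.1-fold lower number from compound 2 to compound 3 (0.05 log units; within the scatter) is expected, that is, no change beyond the scatter in either direction. Compound 3 is therefore estimated at 35000 nM, with a plausible range from 12000 nM to 100000 nM.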

Compound 3, concentration for 50% growth inhibition: 47000 nM
Compound 3: the middle estimate sits 1.3-fold (0.13 log units) below what was measured, and the stated range covers the measured number.
By their numbers in this assay, from the lowest: compounds 2, 3 and 1 (each within the scatter of the next).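

Making the chain that ends in the aromatic ring one link longer gives a 1.2-fold higher number from compound 2 to compound 3 (0.08 log units; within the scatter) in this assay and so does not measurably alter growth inhibition. Within the data shown here, this is the first direct look at this position: the chain that ends in the aromatic ring can be one link longer with no change beyond the scatter. Nothing available here explains this outcome.

Going by these compounds, whether a still longer chain, or an amine or a carboxylic acid in place of the aromatic ring at the end of the chain, would move the number beyond the scatter remains open. A single pair of compounds also cannot establish a trend with chain length.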